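Fluorines on the cyclohexyl: what compound 4 should keep

The compounds below may be only part of what the source reports. "The series", "measured", "known", "first", "only" and "open" are said of these compounds alone.

Of the compounds shown here, three built on one shared core have been tested in an ADME assay on microsomes from liver (Mus musculus) for metabolic stability, read by LC-MS, with a stated time of 10 min; on this read-out higher numbers stand for a more stable compound and lower numbers for a less stable compound. Compound 1 `CCCN(C[C@H]1Cc2c(cccc2N2CCNCC2)CN1)[C@H]1CCCc2cccnc21` gives 87.4%, compound 2 `c1cnc2c(c1)CCC[C@@H]2N(CC1CC1)C[C@H]1Cc2c(cccc2N2CCNCC2)CN1` gives 88.3%, and compound 3 `c1cnc2c(c1)CCC[C@@H]2N(CC1CCCCC1)C[C@H]1Cc2c(cccc2N2CCNCC2)CN1` gives 85.6%, the lowest of the three numbers, though both steps leading to it, a number 1.8 percentage points lower from compound 1 to compound 3 (within the scatter) and a number 2.7 percentage points lower from compound 2 to compound 3 (within the scatter), stay within the scatter, as does a number 0.9 percentage points higher from compound 1 to compound 2 (within the scatter). Compound 4 `FC1(F)CCC(CN(C[C@H]2Cc3c(cccc3N3CCNCC3)CN2)[C@H]2CCCc3cccnc32)CC1` differs from compound 3 in one place: 4,4-difluorocyclohexyl in place of cyclohexyl on a saturated chain carbon bound to an amine nitrogen. Every measured step concerns that same place, and none reached beyond the scatter, so no step beyond the scatter is foreseen for compound 4 either. In this assay compound 4 is expected to give about 85%, between 74% and 94%. The expected step of a number 0.6 percentage points lower from compound 3 to compound 4 (within the scatter) would itself sit within the scatter.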

Compound 4, percent of the compound remaining: 76.6%
Estimate against measurement, compound 4: 8.4 percentage points above; the range from low to high includes it.
By their numbers in this assay, from the lowest: compounds 4, 3, 1 and 2 (each within the scatter of the next, the first and the last beyond it).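

In this assay this place on a saturated chain carbon bound to an amine nitrogen now gives steps that leave the scatter: a number 10.8 percentage points lower from compound 1 to compound 4 (beyond the scatter) and a number 11.7 percentage points lower from compound 2 to compound 4 (beyond the scatter). Adding only the two fluorine atoms to the cyclohexyl gives a number 9 percentage points lower from compound 3 to compound 4 (within the scatter) and so cannot, on its own, be separated from the scatter.

Nothing available bears on the reason for these steps. On these data alone, whether a cyclohexyl carrying a single fluorine or a hydroxyl would stand with compound 3 or with compound 4 remains open.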